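From compound 3 to compound 4 in the antiproliferative read-out

The source may hold more compounds than are shown below. What is called first, only, known or untested is meant among the compounds shown, and "the series" means these compounds.

For the measured compounds named here, in a functional assay on ECa-109 cells (Homo sapiens) for antiproliferative activity, read by MTT assay, with a stated time of 72 h (on this read-out higher numbers stand for weaker inhibition and lower numbers for stronger inhibition), compound 3 (`CCCSc1nc(N/N=C(\C)c2ccccc2O)c2nnn(Cc3ccccc3)c2n1`) gives 11100 nM, the only true number in this small set.

Compound 1 (`CCCSc1nc(N/N=C/c2cccnc2)c2nnn(Cc3ccccc3)c2n1`) reads > 64000 nM, which is a limit.

Compound 2 (`CCCSc1nc(N/N=C/c2cccc(Cl)c2)c2nnn(Cc3ccccc3)c2n1`) reads > 64000 nM, also a limit.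

Compound 4 (`CCCSc1nc(N/N=C/c2ccc(Br)cc2)c2nnn(Cc3ccccc3)c2n1`) departs from compound 3 as follows: a group of 9 heavy atoms (7 carbon, 1 nitrogen, 1 bromine; one six-membered aromatic ring of carbon only) in place of a group of 10 heavy atoms (8 carbon, 1 nitrogen, 1 oxygen; one six-membered aromatic ring of carbon only), on a nitrogen on an aromatic ring.

Going by the values given here, two measured steps bear on this change: an at least 5.7-fold lower number from compound 1 to compound 3 (0.76 log units; beyond the scatter) and an at least 5.7-fold lower number from compound 2 to compound 3 (0.76 log units; beyond the scatter). On these data alone, both are bounded by limits, so their true sizes remain open. The third, a step that the two limits leave unreadable from compound 1 to compound 2, offers no guidance. Among the compounds with values here, the entering group resembles the one in compound 2, with a carbon-only aromatic ring and a single halogen atom. Compound 4 is therefore expected to lose ground relative to compound 3 because an at least 5.7-fold lower number from compound 2 to compound 3 (0.76 log units; beyond the scatter) runs opposite to the present change.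

The expected move in this assay is a 4.1-fold higher number from compound 3 to compound 4 (0.61 log units; beyond the scatter), towards a higher number, and a reading at the limit is quite possible.

For compound 4 the estimated value is 45000 nM, with an expected range of 15000 nM to 100000 nM.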

Compound 4, half-maximal inhibitory concentration: > 64000 nM
Compound 4 ended at the assay's limit (the forecaster's own chance of this, stated with the estimate: 60%); middle value at least 1.4-fold (0.15 log units) away from the limit.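

In this assay, on these data alone, exchanging the group of compound 3 for the one carrying the 4-bromophenyl gives an at least 5.7-fold higher number from compound 3 to compound 4 (0.76 log units; beyond the scatter); this step is bounded by a limit, so its true size stays open. For the compounds shown here, compound 3 remains the only compound with a true number, and a third group on this nitrogen now ends at the limit: the limit of > 64000 nM in this assay, at which 3 of the 4 values shown sit. The steps among compound 1, compound 2 and compound 4 cannot be read, so the pyridin-3-yl, 3-chlorophenyl and 4-bromophenyl groups cannot be ordered.

Which part of the group in compound 3 goes with its lower number, the hydroxyl or the methyl, stays open, as both sit in that one group. Also open, as far as these compounds go, is whether an amine or a carboxylic acid on the phenyl ring would give a true number in this assay.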